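The source may hold more compounds than are shown below. What is called first, only, known or untested is meant among the compounds shown, and "the series" means these compounds.

Measured in a functional assay on MDA-MB-231 cells (Homo sapiens) for inhibition, read by MTT assay, with a stated time of 48 h; a lower number here means a stronger inhibitor, a higher number a weaker inhibitor:
- Compound 1 `COc1cc(/C=C/C(=O)Nc2ccccc2N)ccc1OCC(=O)Nc1cccc(F)c1`: > 100000 nM (a limit, not a number)
- Compound 2 `COc1cc(/C=C/C(=O)Nc2ccccc2N)ccc1OCC(=O)Nc1ccc(Cl)c(Cl)c1`: 83400 nM
- Compound 3 `COc1cc(/C=C/C(=O)NO)ccc1OCC(=O)Nc1ccc(Br)cc1`: 760 nM

Compound 2 gives 83400 nM, the higher of the two actual numbers, and compound 3 gives 760 nM, a gap well beyond the scatter. Compound 4 `COc1ccc(NC(=O)COc2ccc(/C=C/C(=O)Nc3ccccc3N)cc2OC)cc1` has not yet been measured. It differs from compound 2 by 4-methoxyphenyl in place of 3,4-dichlorophenyl on an amide-type nitrogen, with 4-methoxyphenyl in place of 3,4-dichlorophenyl on an amide-type nitrogen.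

Among the compounds with values here, one measured step bears on this change, as it too swaps the group on that nitrogen: an at least 1.1-fold lower number from compound 1 to compound 2 (0.07 log units; that floor lies within the scatter). Its floor lies within the scatter, and it offers no direction for the new group. A step beyond the scatter is therefore not expected in this assay, and neither direction is favoured. The expected outcome is a 1.1-fold higher number from compound 2 to compound 4 (0.03 log units; within the scatter). Compound 4 may also be expected to end at the limit of > 100000 nM in this assay, at which 1 of the 3 values shown sits. For compound 4 the estimated value is 90000 nM, with an expected range of 35000 nM to 200000 nM.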

Compound 4, half-maximal inhibitory concentration: 48500 nM
Beside the measured number, compound 4's estimate is 1.9-fold (0.27 log units) above it, within the range that was stated.
By their numbers in this assay, from the lowest: compound 3; then compounds 4 and 2 (each within the scatter of the next). At a limit, above all of these: compound 1.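

In this assay, 4-methoxyphenyl in place of 3,4-dichlorophenyl on the amide-type nitrogen gives a 1.7-fold lower number from compound 2 to compound 4 (0.24 log units; within the scatter), so compound 2 and compound 4 cannot be placed in any order, even though the two groups differ in their atoms. Set against 3-fluorophenyl, the same group gives an at least 2.0-fold lower number from compound 1 to compound 4 (0.31 log units; beyond the scatter), the first step at this position to clear the scatter, although it is only a floor and a modest one. Compound 1 stands at a limit, not a number: the limit of > 100000 nM in this assay, at which 1 of the 4 values shown sits.

From the compounds shown here alone, what a carboxylic acid or an amine on the aromatic ring at that nitrogen would do in this assay remains open. Also open, going by these compounds, is how 4-bromophenyl at that nitrogen would read on the core of compound 4, as compound 3 differs from compound 4 in more than one place.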